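Ring Expansion at the Aromatic Nitrogen of Compound 1

A few compounds are considered here, and "the series" means these few. Any claim that something is new, unique, unknown or untested is made for them only; others in the source may bear on it.

Compound 1 `O=S(=O)(c1ccccc1F)c1cn(C2CCNC2)c2ncccc12`: 50 nM
Compound 2 `O=S(=O)(Cc1ccc(Cl)s1)c1cn(C2CCNC2)c2ncccc12`: 11 nM
Compound 3 `O=S(=O)(c1cn(C2CCNC2)c2ncccc12)c1cccc2cccnc12`: 643 nM

Of the compounds shown here, three share a core and have been measured in a functional assay on HeLa cells for antagonist activity at 5-hydroxytryptamine receptor 6 (Homo sapiens), read by cAMP accumulation and immunoassay; on this read-out lower numbers stand for stronger inhibition and higher numbers for weaker inhibition. Compound 1 gives 50 nM, the second highest of the three numbers. Its nearest neighbour is compound 2, with a 4.5-fold lower number from compound 1 to compound 2 (0.66 log units; beyond the scatter), a change made on the sulfonyl sulfur. Compound 3 gives 643 nM, the highest number of the set, and differs from compound 1 at the same sulfonyl position, so it too says nothing about the group on the aromatic nitrogen.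

Compound 4 `O=S(=O)(c1ccccc1F)c1cn(C2CCCNC2)c2ncccc12` keeps the 2-fluorophenyl sulfonyl of compound 1 and differs only in that group: piperidin-3-yl in place of pyrrolidin-3-yl on an aromatic nitrogen. For the measured compounds named here, none of the measured steps touches this position; the only step, from compound 1 to compound 2, concerns the sulfonyl substituent and cannot be carried over. The change keeps the donor and acceptor count and adds one ring atom, so no step beyond the scatter is expected in this assay, with a wide range to reflect the absence of a precedent. Compound 4 is therefore estimated at 70 nM, between 20 nM and 250 nM, which would mean a 1.4-fold higher number from compound 1 to compound 4 (0.15 log units; within the scatter).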

Compound 4, half-maximal inhibitory concentration: 50 nM
The estimate for compound 4 lay 1.4-fold (0.15 log units) above the measured number; low and high end bracket the measured number.
By their numbers in this assay, from the lowest: compound 2; then compounds 1 and 4 (each within the scatter of the next); then compound 3.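

In this assay, piperidin-3-yl in place of pyrrolidin-3-yl on an aromatic nitrogen gives no change at the digits printed from compound 1 to compound 4 (within the scatter) and provides the only reading at this position among the compounds shown. With the 2-fluorophenyl sulfonyl group held constant, the six-membered non-aromatic ring therefore serves as well as the five-membered one in this read-out, whereas the change on the sulfonyl sulfur gives a 4.5-fold lower number from compound 1 to compound 2 (0.66 log units; beyond the scatter) and lies beyond the scatter. No measurement among those given bears on why the two rings read alike.

The compounds shown leave open whether the same ring change would also read alike with the (5-chlorothiophen-2-yl)methyl group of compound 2 or with the sulfonyl substituent of compound 3, since this pair alone carries the piperidin-3-yl comparison. They also leave open how far this position tolerates other change, for example a methyl group on the ring nitrogen of piperidin-3-yl or an open, longer chain ending in an amine on the aromatic nitrogen.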